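Trifluoromethyl in place of bromo on a series at the limit

The source may report more compounds than this note shows. Statements on the series, on what has been measured and on what is new or still open speak of the compounds shown alone.

Compound 1 `C=C1C[C@]23C[C@@]1(O)CC[C@H]2c1ccc(OS(=O)(=O)c2ccc(C)cc2)c(C)c1[C@@H]3Cn1cc(-c2ccc(Br)cc2)nn1` carries a (4-methylphenyl)sulfonyl on an oxygen on an aromatic ring and a 4-bromophenyl at the far end. In a functional assay on A549 cells (Homo sapiens) for cytotoxicity, read by MTT assay, with a stated time of 4 days (a lower number here means a stronger inhibitor, a higher number a weaker inhibitor), compound 1 gives only a limit, > 20000 nM, with no number behind it. Compound 2 `C=C1C[C@]23C[C@@]1(O)CC[C@H]2c1ccc(O)c(C)c1[C@@H]3Cn1cc(-c2ccc(Br)cc2)nn1`, with hydrogen in place of that sulfonyl, is likewise reported only as a limit in this assay, > 20000 nM. Compound 3 `C=C1C[C@]23C[C@@]1(O)CC[C@H]2c1cc(Br)c(O)c(C)c1[C@@H]3Cn1cc(-c2ccc(C)cc2)nn1`, with a further bromo on the core and a different aryl at the far end, also reaches only the limit in this assay, > 20000 nM. Among the measured compounds shown here, the one step read between neighbours, a step that the two limits leave unreadable from compound 1 to compound 2, has both ends at a limit and so has no readable size. This is the whole picture: the limit of > 20000 nM in this assay, at which 3 of the 3 values shown sit, so compound 1 stands at the top of the range and no measured difference separates it from compound 2 or compound 3.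

Compound 4 `C=C1C[C@]23C[C@@]1(O)CC[C@H]2c1ccc(OS(=O)(=O)c2ccc(C)cc2)c(C)c1[C@@H]3Cn1cc(-c2ccc(C(F)(F)F)cc2)nn1` differs from compound 1 by trifluoromethyl in place of bromo on an aromatic carbon. For the measured compounds named here, no measured step touches this position, and the three values at the limit give neither direction nor size. The expectation is therefore that compound 4 stays at the limit as well, the estimated step that the limit leaves unreadable from compound 1 to compound 4 being nothing beyond the scatter. Compound 4 is estimated at 30000 nM in this assay, within 12000 nM to 100000 nM.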

Compound 4, half-maximal inhibitory concentration: > 20000 nM
Compound 4: a limit, no number; the forecaster's own chance of this, stated with the estimate: 85%; the middle value is on the limit's open side.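

No new step can be read between compound 1 and compound 4, since each is reported only as a limit and not as a number: the limit of > 20000 nM in this assay, at which 4 of the 4 values shown sit.

The compounds shown leave open whether any change to the shared core or to the aryl group at the far end would give a readable value in this assay.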